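Swapping the hydrazone aryl group on a weak antiproliferative series

This account rests on a few compounds, and the source may have more. Where it says the series, first, only, none or still open, it means among the compounds named here.

In a functional assay on PC-3 cells (Homo sapiens) for antiproliferative activity, read by MTT assay (a higher number here means a weaker inhibitor, a lower number a stronger inhibitor), compound 1 `Cc1cccc(/C=N/Nc2ncc3c(n2)n(C2CCCC2)c(=O)c(=O)n3C)c1` gives 53600 nM.
In this assay compound 2 `Cc1ccc(/C=N/Nc2ncc3c(n2)n(C2CCCC2)c(=O)c(=O)n3C)cc1C` gives 39000 nM.

Compound 2 holds the lower of the two numbers, but the step of a 1.4-fold lower number from compound 1 to compound 2 (0.14 log units; within the scatter) lies within the scatter, so the two stand level. Compound 3 `Cn1c(=O)c(=O)n(C2CCCC2)c2nc(N/N=C/c3ccccc3Cl)ncc21` differs from compound 2 by 2-chlorophenyl in place of 3,4-dimethylphenyl on a carbon with a double bond to nitrogen. Going by the values given here, the only measured step, a 1.4-fold lower number from compound 1 to compound 2 (0.14 log units; within the scatter), concerns a methyl on an aromatic carbon and was within the scatter; nothing measured bears on replacing the whole aryl ring. Compound 3 is therefore expected to land near compound 2, a step of a 1.0-fold higher number from compound 2 to compound 3 (0.01 log units; within the scatter) not beyond the scatter. Compound 3 is estimated at 40000 nM, in the range 15000 nM to 110000 nM.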

Compound 3, half-maximal inhibitory concentration: 16300 nM
The estimate for compound 3 lay 2.5-fold (0.39 log units) above the measured number; the measured number falls inside the stated range.
By their numbers in this assay, from the lowest: compound 3; then compounds 2 and 1 (each within the scatter of the next).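

In this assay the aryl group on the carbon with a double bond to nitrogen now makes a difference beyond the scatter, with a 2.4-fold lower number from compound 2 to compound 3 (0.38 log units; beyond the scatter) and a 3.3-fold lower number from compound 1 to compound 3 (0.52 log units; beyond the scatter) as modest steps. The earlier methyl change showed no such movement, so this position does respond when 2-chlorophenyl replaces either methyl-bearing ring. The data shown offer no explanation for this gain.

The compounds leave open whether the chlorine itself or the absence of the methyl groups accounts for the lower number. They also leave open how a ring bearing a methoxy group, a nitrile or an amine would behave.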